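From 3-chlorobenzyl to 3-bromobenzyl: a small step expected

This account rests on a few compounds, and the source may have more. Where it says the series, first, only, none or still open, it means among the compounds named here.

Of the compounds shown here, three sharing one core have been tested in a functional assay on HepG2 cells (Homo sapiens) for inhibition, read by MTT assay, with a stated time of 48 h; on this read-out lower numbers stand for stronger inhibition and higher numbers for weaker inhibition. Compound 1 `Fc1ccccc1CSc1nnc(-c2ccncc2)n1-c1ccccc1` gives > 50000 nM, which is a limit of the assay and not a number. Compound 2 `Clc1ccccc1CSc1nnc(-c2ccncc2)n1-c1ccccc1` gives 15700 nM, and compound 3 `Clc1cccc(CSc2nnc(-c3ccncc3)n2-c2ccccc2)c1` gives 11200 nM. These last two numbers cannot be told apart, since 3-chlorophenyl in place of 2-chlorophenyl gives a 1.4-fold lower number from compound 2 to compound 3 (0.15 log units; within the scatter).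

Compound 4 `Brc1cccc(CSc2nnc(-c3ccncc3)n2-c2ccccc2)c1` has not yet been measured. It differs from compound 3 by bromo in place of chloro on an aromatic carbon, which is bromo in place of chloro on an aromatic carbon. The closest measured change is chloro in place of fluoro, which gives an at least 3.1-fold lower number from compound 1 to compound 2 (0.50 log units; beyond the scatter). A related change gives an at least 4.4-fold lower number from compound 1 to compound 3 (0.64 log units; beyond the scatter). Both steps start from a limit and involve a different halogen exchange, so they are only a loose guide. In this assay, a small shift towards lower numbers is expected, probably not beyond the scatter. The estimated step is a 1.1-fold lower number from compound 3 to compound 4 (0.05 log units; within the scatter). The expected value for compound 4 is 10000 nM, with an estimated range of 5000 nM to 21000 nM.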

Compound 4, half-maximal inhibitory concentration: 7040 nM
Beside the measured number, compound 4's estimate is 1.4-fold (0.15 log units) above it, within the range that was stated.
By their numbers in this assay, from the lowest: compounds 4, 3 and 2 (each within the scatter of the next, the first and the last beyond it). At a limit, above all of these: compound 1.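

In this assay, bromo in place of chloro on the aromatic carbon gives a 1.6-fold lower number from compound 3 to compound 4 (0.20 log units; within the scatter), so at this position the two halogens cannot be told apart. Changing both the halogen and its place on the ring, however, gives a 2.2-fold lower number from compound 2 to compound 4 (0.35 log units; beyond the scatter), a modest step beyond the scatter, although a single step cannot show which of the two changes accounts for it. The remaining step, an at least 7.1-fold lower number from compound 1 to compound 4 (0.85 log units; beyond the scatter), starts from a limit of the assay and not from a number: the limit of > 50000 nM in this assay, at which 1 of the 4 values shown sits.

As far as these compounds go, whether iodo, methoxy or an amine at this same place would shift the number further remains open. What a carboxylic acid elsewhere on the shared core would do is also unknown.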